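Aryl substituent swaps in a cytotoxicity screen

The compounds below may be only part of what the source reports. "The series", "measured", "known", "first", "only" and "open" are said of these compounds alone.

Measured compounds:
compound 1 `CCOC(=O)c1c(-c2cccc(-c3ccccc3)c2)[nH]c2cc(OC)ccc2c1=O`: > 21500 nM, a limit of the assay
compound 2 `CCOC(=O)c1c(-c2cccc(-c3ccccc3)c2)[nH]c2cc(Cl)ccc2c1=O`: > 21500 nM, a limit of the assay
compound 3 `CCOC(=O)c1c(-c2cccc(-c3ccccc3)c2)[nH]c2cc(OC)c(OC)cc2c1=O`: > 21500 nM, a limit of the assay

In an ADME assay on HepG2 cells (Homo sapiens) for cytotoxicity, read by luminescence, with a stated time of 72 h (on this read-out lower numbers stand for an effect already at smaller amounts and higher numbers for an effect only at larger amounts of compound), all three measured compounds stand at one and the same limit, (the limit of > 21500 nM in this assay, at which 3 of the 3 values shown sit). The steps between them therefore cannot be sized: a step that the two limits leave unreadable from compound 1 to compound 2, made by chloro in place of methoxy on an aromatic carbon; and a step that the two limits leave unreadable from compound 1 to compound 3, made by methoxy in place of hydrogen on an aromatic carbon. The last of these is also how the core of compound 3 differs from the core of compound 1.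

Compound 4 `CCOC(=O)c1c(-c2cccc(-c3ccccc3)c2)[nH]c2cc(Cl)c(OC)cc2c1=O` is not yet measured. It differs from compound 3 by chloro in place of methoxy on an aromatic carbon. Among the compounds with values here, this is the same kind of change as the one from compound 1 to compound 2, but not the same: in compound 4 the carbon that receives the chloro group is ortho to a methoxy group, which is not so in compound 2.

For compound 4 a step that the limit leaves unreadable from compound 3 to compound 4 is expected in this assay. The expectation rests on compound 3, which gives > 21500 nM, a limit. It rests also on compound 2, which gives > 21500 nM, a limit, after the same kind of change. Compound 4 is therefore estimated at 30000 nM, with 15000 nM to 100000 nM as the expected range, and most likely only a limit will be reported.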

Compound 4, half-maximal effective concentration: > 21500 nM
Compound 4 gave a limit, no number (the forecaster's own chance of this, stated with the estimate: 85%); the middle value lies beyond the limit too.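

No new step can be read between compound 4 and either compound 3 or compound 2, because all the values are limits and not numbers: the limit of > 21500 nM in this assay, at which 4 of the 4 values shown sit.

The compounds shown leave open whether chloro or methoxy on the shared core makes any difference in this assay, and how large any difference among compound 1, compound 2, compound 3 and compound 4 would be.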